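Aryl Exchange on a Free Fatty Acid Receptor 1 Series

The compounds below may be only part of what the source reports. "The series", "measured", "known", "first", "only" and "open" are said of these compounds alone.

Two compounds have been measured in a functional assay on CHO cells for agonist activity at Free fatty acid receptor 1 (Homo sapiens), read by FLIPR and calcium flux, tested at 100 nM; on this read-out lower numbers stand for a weaker effect and higher numbers for a stronger effect at the one concentration tested:

compound 1 `Cc1nc(-c2ccccc2)sc1COc1ccc2c(c1)OCC2CC(=O)O` gives 54.8%
compound 2 `Cc1nc(-c2ccsc2)sc1COc1ccc2c(c1)OCC2CC(=O)O` gives 56.5%

Compound 2 stands level with compound 1 in this assay, the step of a number 1.7 percentage points higher from compound 1 to compound 2 (within the scatter) being the only one recorded, and it lies within the scatter. The unmeasured compound 3 `Cc1nc(-c2ccc(Cl)s2)sc1COc1ccc2c(c1)OCC2CC(=O)O` differs from compound 2 in one place: 5-chlorothiophen-2-yl in place of thiophen-3-yl on an aromatic carbon. Going by the values given here, the single step that bears on this change is the exchange of the same aryl group at the same place, from compound 1 to compound 2, and it produced nothing beyond the scatter. Among the compounds with values here, with only that step to go on, the expectation for compound 3 in this assay is a step of a number 1.5 percentage points lower from compound 2 to compound 3 (within the scatter), that is, no change beyond the scatter. Compound 3 is therefore estimated at 55%, within a range from 35% to 75%.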

Compound 3, a percentage reported as activity, at one concentration (the size of the read-out at that concentration, not a potency): 8.34%
Compound 3: middle estimate off by 46.7 percentage points, on the high side; measured number outside the range, below it.
By their numbers in this assay, from the lowest: compound 3; then compounds 1 and 2 (each within the scatter of the next).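

In this assay, this position, on an aromatic carbon next to the ring nitrogen and next to the ring sulfur, turns out not to accept every aryl group equally. Phenyl and thiophen-3-yl had read alike, but 5-chlorothiophen-2-yl brings a number 48.2 percentage points lower from compound 2 to compound 3 (beyond the scatter) and a number 46.5 percentage points lower from compound 1 to compound 3 (beyond the scatter), so the level step seen earlier does not extend to this group. No measurement is available that accounts for the drop.

The compounds shown change the chlorine and the point of attachment of the thiophene together, which leaves open which of the two goes with the drop. Also open, as far as these compounds go, is how thiophen-2-yl without the chlorine, or 4-chlorophenyl, would read at this place.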